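This account rests on a few compounds, and the source may have more. Where it says the series, first, only, none or still open, it means among the compounds named here.

Measured compounds in a functional assay on K562 cells (Homo sapiens) for inhibition; on this read-out higher numbers stand for weaker inhibition and lower numbers for stronger inhibition:
compound 1 `CC(C)c1ccc(N2C(=O)C=CC2OCC(F)(F)F)cc1` gives 6620 nM;
compound 2 `Cc1ccc(N2C(=O)C=CC2OCC(F)(F)F)cc1` gives 7140 nM;
compound 3 `O=C1C=CC(OCC(F)(F)F)N1c1ccccc1` gives 24600 nM.

Among these three, compound 3 shows the highest number in this assay; compound 2 lies nearest to it and compound 1 furthest, both gaps beyond the scatter. Compound 3 differs from the other two only at one aromatic carbon, where it carries hydrogen instead of methyl or isopropyl.

The untested compound 4 `O=C1C=CC(OCC(F)(F)F)N1c1ccc([N+](=O)[O-])cc1` differs from compound 3 by nitro in place of hydrogen on an aromatic carbon. Among the measured compounds shown here, no measured pair shows a nitro group entering or leaving, so the steps that bear on this change are those in which a substituent at the same aromatic carbon is removed: a 3.7-fold higher number from compound 1 to compound 3 (0.57 log units; beyond the scatter) and a 3.4-fold higher number from compound 2 to compound 3 (0.54 log units; beyond the scatter). Both removals raised the number by a modest but real amount, while a 1.1-fold higher number from compound 1 to compound 2 (0.03 log units; within the scatter) shows that methyl and isopropyl give numbers within the scatter of each other. For the measured compounds named here, whether a nitro group behaves like those two groups cannot be read from three compounds; the only guidance is that filling this position has so far lowered the number. Compound 4 is thus expected to give a somewhat lower number than compound 3 in this assay, a step of about a 2.1-fold lower number from compound 3 to compound 4 (0.31 log units; beyond the scatter), with wide uncertainty. The estimate for compound 4 is 12000 nM, within a range from 4000 nM to 40000 nM.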

Compound 4, half-maximal inhibitory concentration: 1530 nM
For compound 4 the middle estimate is 7.8-fold (0.89 log units) above the measured one, outside the stated range (below it).
By their numbers in this assay, from the lowest: compound 4; then compounds 1 and 2 (each within the scatter of the next); then compound 3.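

Nitro on this aromatic carbon gives a 16-fold lower number from compound 3 to compound 4 (1.21 log units; beyond the scatter) in this assay, so the position can move the number much further than methyl or isopropyl had suggested. Nitro also separates clearly from those two groups in this assay: replacing methyl with nitro gives a 4.7-fold lower number from compound 2 to compound 4 (0.67 log units; beyond the scatter) and replacing isopropyl with nitro gives a 4.3-fold lower number from compound 1 to compound 4 (0.64 log units; beyond the scatter), although methyl and isopropyl lie within the scatter of each other. The earlier compounds shown here showed only that a substituent here lowers the number relative to hydrogen, whereas compound 4 shows that the identity of the group also matters, and it has the lowest number of the four compounds.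

The compounds shown leave open how an amine, a nitrile or a carboxylic acid on this carbon would compare with nitro, and whether nitro on another carbon of the aromatic ring would lower the number as well. No measurement is available here that would explain the result.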